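This account rests on a few compounds, and the source may have more. Where it says the series, first, only, none or still open, it means among the compounds named here.

Compound 3 `COc1cccc(S(=O)(=O)N2CCC(N3CCC(C)CC3)CC2)c1` carries a methoxy on the aromatic carbon of the sulfonyl-bearing ring. In a functional assay on DLD-1 cells (Homo sapiens) for antiproliferative activity, read by CellTiter-Glo, with a stated time of 72 h (on this read-out lower numbers stand for stronger inhibition and higher numbers for weaker inhibition), compound 3 gives only a limit of the assay, > 5000 nM, and no number. That value sits at the limit of > 5000 nM in this assay, at which 1 of the 3 values shown sits, so compound 3 stands at the weak end of the three measured compounds. The two numbers that exist are those of compound 1 `CC1CCN(C2CCN(S(=O)(=O)c3cccc(N)c3)CC2)CC1` with 3400 nM and of compound 2 `Cc1cccc(S(=O)(=O)N2CCC(N3CCC(C)CC3)CC2)c1` with 25 nM. The steps among them are uneven: a 140-fold lower number from compound 1 to compound 2 (2.13 log units; beyond the scatter), an at least 1.4-fold higher number from compound 1 to compound 3 (0.16 log units; that floor lies within the scatter), and an at least 200-fold higher number from compound 2 to compound 3 (2.30 log units; beyond the scatter).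

Compound 4 `CC1CCN(C2CCN(S(=O)(=O)c3cccc(-c4ccccc4)c3)CC2)CC1` is the next candidate; the change from compound 3 is phenyl in place of methoxy on an aromatic carbon. The step that bears on it most directly is an at least 200-fold higher number from compound 2 to compound 3 (2.30 log units; beyond the scatter), which shows that a single swap of the group at this position can shift the number by a large amount, and a 140-fold lower number from compound 1 to compound 2 (2.13 log units; beyond the scatter) points the same way. For the measured compounds named here, no measured step involves a phenyl at this position, so the direction rests on the methyl result of compound 2 alone and carries wide uncertainty.

Compound 4 is therefore expected to give 500 nM, within a range of 40 nM to 5000 nM, that is, an estimated step of an at least 10-fold lower number from compound 3 to compound 4 (1.00 log units; beyond the scatter).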

Compound 4, half-maximal inhibitory concentration: 2 nM
Compound 4: the middle estimate sits 250-fold (2.40 log units) above what was measured; measured number below the stated range.
By their numbers in this assay, from the lowest: compound 4; then compound 2; then compound 1. At a limit, above all of these: compound 3.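

In this assay, the step of an at least 2500-fold lower number from compound 3 to compound 4 (3.39 log units; beyond the scatter) can only be read as a floor, since compound 3 gives no number, only a limit: the limit of > 5000 nM in this assay, at which 1 of the 4 values shown sits. The earlier compounds shown here carried only amino, methyl or methoxy on this aromatic carbon, and the phenyl shows that the position also accepts an added six-membered aromatic ring, with a further gain over the best small group: a 13-fold lower number from compound 2 to compound 4 (1.10 log units; beyond the scatter), and against the amino compound, a 1700-fold lower number from compound 1 to compound 4 (3.23 log units; beyond the scatter). The numbers do not follow group size alone, as compound 3, with its methoxy, goes against any simple rise in strength from methyl to phenyl.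

On these data alone, it remains open whether the gain depends on the aromatic ring itself or only on the size of the group, a question that a cyclohexyl ring or a longer chain such as butyl on the same carbon would address. Also open, as far as these compounds go, is how far the phenyl tolerates further substitution, for example a carboxylic acid or an amine on the added ring, and what any of these changes would do in a read-out other than this antiproliferative one.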